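The source may report more compounds than this note shows. Statements on the series, on what has been measured and on what is new or still open speak of the compounds shown alone.

Measured compounds:
compound 1 `CC(=O)Oc1ccccc1C(=O)O[C@H]1CO[C@H]2[C@@H]1OC[C@H]2OC(=O)C1CC1`: 0.0322 h
compound 2 `CC(=O)Oc1ccccc1C(=O)O[C@H]1CO[C@H]2[C@@H]1OC[C@H]2OC(=O)c1ccc(C)cc1`: 0.105 h

In an ADME assay on a cell-free system (plasma, Homo sapiens) for metabolic stability, with Plasma (Rattus norvegicus) as the target, read by HPLC, at pH 7.4 (a higher number here means that the compound lasts longer, a lower number that the compound disappears faster), compound 2 stands highest of the two numbers; its nearest neighbour is compound 1, and a 3.3-fold higher number from compound 1 to compound 2 (0.51 log units; beyond the scatter) separates them. Compound 3 `CC(=O)Oc1ccccc1C(=O)O[C@H]1CO[C@H]2[C@@H]1OC[C@H]2OC(=O)c1ccccc1CO[N+](=O)[O-]` differs from compound 2 in one place: 2-((nitrooxy)methyl)phenyl in place of 4-methylphenyl on a carbonyl carbon. For the measured compounds named here, no measured step changes an aromatic ring in this way, so the one step from compound 1 to compound 2 does not bear directly on it, and the half-life of compound 3 is expected to stay near that of compound 2, with a 1.3-fold lower number from compound 2 to compound 3 (0.12 log units; within the scatter) as the estimated step. Compound 3 is therefore estimated at 0.08 h, within 0.03 h to 0.2 h.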

Compound 3, half-life: 0.045 h
The estimate for compound 3 lay 1.8-fold (0.25 log units) above the measured number, and the stated range covers the measured number.
By their numbers in this assay, from the lowest: compounds 1 and 3 (each within the scatter of the next); then compound 2.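

In this assay, the aromatic group on this carbonyl carbon matters: 2-((nitrooxy)methyl)phenyl in place of 4-methylphenyl gives a 2.3-fold lower number from compound 2 to compound 3 (0.37 log units; beyond the scatter). An aromatic ring here therefore does not by itself keep the number up, since a 1.4-fold higher number from compound 1 to compound 3 (0.15 log units; within the scatter) leaves the new group level with cyclopropyl. No evidence at hand bears on the reason for either step.

The compounds shown do not separate the nitrooxy part of the new group from the place it holds on the ring. Also open, on these data alone, is how an amine or a carboxylic acid on that ring, or a longer chain on the carbonyl carbon, would change the half-life.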